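From fluoro to methoxy on the aromatic ring

The compounds below may be only part of what the source reports. "The series", "measured", "known", "first", "only" and "open" are said of these compounds alone.

In a functional assay on ECa-109 cells for inhibition, with ECa-109 cell line (Homo sapiens) as the target, read by sulforhodamine B assay (a lower number here means a stronger inhibitor, a higher number a weaker inhibitor), compound 1 (`O=C1C(Nc2ccccc2)=CC(=O)c2c1nc1n2[C@H]2OC[C@@H](O)[C@H]2OC1`) gives 3560 nM. Compound 2 (`CCc1ccc(NC2=CC(=O)c3c(nc4n3[C@H]3OC[C@@H](O)[C@H]3OC4)C2=O)cc1`) reads > 4000 nM, which is a limit of the assay and not a number. Compound 3 (`O=C1C=C(Nc2ccccc2F)C(=O)c2c1nc1n2[C@H]2OC[C@@H](O)[C@H]2OC1`) gives 2760 nM, and its gap to compound 1, the nearest number, lies within the scatter, so these two values are not separated.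

Compound 4 (`COc1ccccc1NC1=CC(=O)c2nc3n(c2C1=O)[C@H]1OC[C@@H](O)[C@H]1OC3`) follows from compound 3 by one change: methoxy in place of fluoro on an aromatic carbon. In words, this is methoxy in place of fluoro on an aromatic carbon, ortho to a large group.

Going by the values given here, only one measured step bears on this, and only loosely: an at least 1.1-fold higher number from compound 1 to compound 2 (0.05 log units; that floor lies within the scatter). From the compounds shown here alone, that step puts ethyl in place of hydrogen on an aromatic carbon, so it is a different exchange, and its full size is unknown. Among the compounds with values here, no measured step covers the exchange of fluoro for methoxy. The expectation therefore rests on compound 3 at 2760 nM and on the narrow spread of the numbers in this assay. The expected change is a 1.2-fold higher number from compound 3 to compound 4 (0.06 log units; within the scatter), with no shift beyond the scatter foreseen in either direction. A report of a limit alone remains possible. For compound 4 the estimated value is 3200 nM, with an expected range of 1800 nM to 5500 nM.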

Compound 4, half-maximal inhibitory concentration: > 4000 nM
Compound 4 ended at the assay's limit (the forecaster's own chance of this, stated with the estimate: 30%); middle value at least 1.2-fold (0.09 log units) from the limit.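

In this assay compound 4 stands as > 4000 nM, a limit of the assay and not a number. Read from that limit, the exchange of fluoro for methoxy, ortho to a large group, gives an at least 1.4-fold higher number from compound 3 to compound 4 (0.16 log units; that floor lies within the scatter), so this is only a floor on the step, and that floor does not separate the 2-methoxyphenyl compound from the 2-fluorophenyl compound; the true size of the step may be larger, but the data cannot fix it. What this adds to the earlier compounds is a first measured exchange at this place on the aromatic ring, and it yields a second reading at the limit rather than a number that could be ranked: the limit of > 4000 nM in this assay, at which 2 of the 4 values shown sit.

Still open, from the compounds shown here alone, is how far compound 4 lies past the limit, and therefore whether methoxy at this place changes the reading at all. Also open, going by these compounds, is whether a chloro, hydroxy or dimethylamino group at the same place, or a carboxylic acid or a longer chain such as propyl, would give a reading that can be compared with compound 3.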